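Two Methoxy Groups in Place of Two Chlorines

The source may report more compounds than this note shows. Statements on the series, on what has been measured and on what is new or still open speak of the compounds shown alone.

Of the compounds shown here, three sharing one core have been tested in a functional assay on PC-3 cells (Homo sapiens) for cytotoxicity, read by sulforhodamine B assay, with a stated time of 48 h; a lower number here means a stronger inhibitor of growth, a higher number a weaker inhibitor of growth. Compound 1 `COc1ccc(-c2cs/c(=N\NC(=O)c3ccc(O)cc3)n2-c2ccc(OC)cc2OC)cc1` gave only a limit of the assay, < 100000 nM, rather than a number. Compound 2 `O=C(N/N=c1\scc(-c2ccc(Cl)cc2)n1-c1ccc(Cl)cc1Cl)c1ccc(O)cc1` likewise returned only the assay limit of < 100000 nM in this assay. Among the measured compounds shown here, compound 3 `Cc1ccc(-c2cs/c(=N\NC(=O)c3ccc(O)cc3)n2-c2c(C)cccc2C)cc1` is the single member with an actual number, at 91200 nM in this assay. So compound 2 stands at the edge of what this assay can report, a place shared with one other compound (the limit of < 100000 nM in this assay, at which 2 of the 3 values shown sit), and the one real number in the set lies close to that edge.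

Compound 4 `COc1ccc(-n2c(-c3ccc(Cl)cc3)cs/c2=N\NC(=O)c2ccc(O)cc2)c(OC)c1` is reached from compound 2 by a single change: 2,4-dimethoxyphenyl in place of 2,4-dichlorophenyl on an aromatic nitrogen. For the measured compounds named here, no step between two measured compounds is available to show what this swap does. Compound 1 carries the same 2,4-dimethoxyphenyl on the aromatic nitrogen and gave only the limit < 100000 nM. Compound 4 is therefore expected to stay weak, with the step from compound 2 to compound 4 estimated as a step that the limit leaves unreadable from compound 2 to compound 4, meaning nothing beyond the scatter. The estimate for compound 4 in this assay is 85000 nM, with a range from 30000 nM to 250000 nM, and a real chance that only a limit is reported again.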

Compound 4, concentration for total growth inhibition: < 100000 nM
Compound 4 was reported as a limit; the forecaster's own chance of this, stated with the estimate: 60%; the middle value is on the limit's open side.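

Compound 4 returned only a limit, as did compound 1 and compound 2, so no step from either compound to compound 4 can be read in this assay: the limit of < 100000 nM in this assay, at which 3 of the 4 values shown sit.

The compounds shown leave open whether 2,4-dimethoxyphenyl in place of 2,4-dichlorophenyl, or chloro in place of methoxy, changes growth inhibition at all.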